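The compounds below may be only part of what the source reports. "The series", "measured", "known", "first", "only" and "open" are said of these compounds alone.

Measured in a functional assay on Malme-3M cells (Homo sapiens) for cytotoxicity, read by MTT assay, with a stated time of 6 days (a higher number here means that more compound is needed for the effect, a lower number that less compound is needed), each value a limit and not a number:

- Compound 1 `COC(=O)c1c(-c2cc(OC)cc(OC)c2)oc2ccccc2c1=O`: > 25 ug/mL
- Compound 2 `COC(=O)c1c(-c2ccc(Br)cc2)oc2ccccc2c1=O`: > 25 ug/mL
- Compound 3 `COc1cc(-c2oc3ccccc3c(=O)c2C(=O)O)cc(OC)c1OC`: > 25 ug/mL

Compound 3 has no numerical value in this assay, only this limit, and it shares that limit with compounds 1 and 2. The next compound is compound 4 `COc1cc(OC)cc(-c2oc3ccccc3c(=O)c2C(=O)O)c1`, which carries hydrogen in place of methoxy on an aromatic carbon, ortho to two methoxy groups and para to a large group: hydrogen in place of methoxy on an aromatic carbon. Within the data shown here, no measured step gives the size of such a change. Among the measured compounds shown here, the only guide is the limit of > 25 ug/mL in this assay, at which 3 of the 3 values shown sit, so no change beyond the scatter is expected, in either direction. The estimated step is a step that the limit leaves unreadable from compound 3 to compound 4. Compound 4 is expected at 30 ug/mL, with an estimated range from 15 ug/mL to 60 ug/mL.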

Compound 4, concentration for half-maximal effect: > 25 ug/mL
Compound 4: a limit, no number; the forecaster's own chance of this, stated with the estimate: 85%; the middle value lies beyond the limit too.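

Compound 4 gives only a limit, as do compound 1 and compound 3, so the steps from compound 3 and compound 1 to compound 4 cannot be read. The compounds shown leave open whether any substitution changes the result in this assay: the limit of > 25 ug/mL in this assay, at which 4 of the 4 values shown sit.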